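Amide variation in the series: solubility working notes

A few compounds are considered here, and "the series" means these few. Any claim that something is new, unique, unknown or untested is made for them only; others in the source may bear on it.

Measured so far:
compound 1, `O=C(c1ccc(Cl)cc1)N1CCN(c2nc(=O)c3cc(C(F)(F)F)cc([N+](=O)[O-])c3s2)CC1`: 5.19 ug/mL
compound 2, `O=C(c1ccccc1Cl)N1CCN(c2nc(=O)c3cc(C(F)(F)F)cc([N+](=O)[O-])c3s2)CC1`: 8.18 ug/mL

In a physicochemical assay for solubility, read by HPLC (a higher number here means a more soluble compound, a lower number a less soluble compound), compound 2 gives 8.18 ug/mL; its nearest neighbour is compound 1, and a 1.6-fold higher number from compound 1 to compound 2 (0.20 log units; within the scatter) lies within the scatter, so the two are not distinguished. Compound 3, `CCC(C)C(=O)N1CCN(c2nc(=O)c3cc(C(F)(F)F)cc([N+](=O)[O-])c3s2)CC1`, differs from compound 2 by sec-butyl in place of 2-chlorophenyl on a carbonyl carbon. For the measured compounds named here, the only measured step moved a chlorine on the phenyl and does not bear on exchanging that ring for a chain, so no measured step informs this change and the expectation is weak. A modest rise is expected, a 1.8-fold higher number from compound 2 to compound 3 (0.26 log units; within the scatter), and compound 3 is estimated at 15 ug/mL, range 5 ug/mL to 45 ug/mL.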

Compound 3, solubility: 104 ug/mL
Estimate against measurement, compound 3: 6.9-fold (0.84 log units) below; the measured number lies above the stated range.
By their numbers in this assay, from the lowest: compounds 1 and 2 (each within the scatter of the next); then compound 3.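

In this assay the substituent on the amide carbonyl carbon can shift the read-out strongly: a 13-fold higher number from compound 2 to compound 3 (1.10 log units; beyond the scatter) and a 20-fold higher number from compound 1 to compound 3 (1.30 log units; beyond the scatter) are both large and beyond the scatter, whereas moving the chlorine on the phenyl stayed within it. Both steps exchange a chlorophenyl ring for sec-butyl, so this change holds for either chlorine placement. No measurement available here accounts for the size of these steps. Still open, as far as these compounds go, is whether unsubstituted phenyl, cyclohexyl or a longer chain would match sec-butyl, so loss of the aromatic ring and loss of chlorine remain unseparated.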